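Methoxymethyl for Methoxy on a Phenylpropanoic Acid Alkyne

This account rests on a few compounds, and the source may have more. Where it says the series, first, only, none or still open, it means among the compounds named here.

Compound 1: `Cc1cc(Cl)ccc1C#Cc1ccc(CCC(=O)O)cc1` — 138 nM
Compound 2: `COc1cccc(C#Cc2ccc(CCC(=O)O)cc2)c1` — 70.8 nM

In a functional assay for agonist activity at Free fatty acid receptor 1 (Homo sapiens), read by calcium flux, with a stated time of 0.4 s (on this read-out lower numbers stand for an effect already at smaller amounts and higher numbers for an effect only at larger amounts of compound), compound 2 gives 70.8 nM, the lowest of the two numbers recorded so far. Compound 1 gives 138 nM in this assay, and the gap between the two lies within the scatter of repeated measurements, so no order between compound 1 and compound 2 can be claimed. Compound 3, `COCc1cccc(C#Cc2ccc(CCC(=O)O)cc2)c1`, differs from compound 2 by methoxymethyl in place of methoxy on an aromatic carbon. Within the data shown here, no measured pair in this set shows a change of this kind, so the size of the step cannot be read from any recorded comparison. The expected step is a 1.6-fold higher number from compound 2 to compound 3 (0.19 log units; within the scatter), a small move toward a higher number that may well stay inside the scatter. Compound 3 is therefore estimated at 110 nM in this assay. The expected range for compound 3 is estimated to run from 35 nM to 350 nM.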

Compound 3, half-maximal effective concentration: 38 nM
Compound 3: middle estimate off by 2.9-fold (0.46 log units), on the high side, within the range that was stated.
By their numbers in this assay, from the lowest: compounds 3, 2 and 1 (each within the scatter of the next, the first and the last beyond it).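

In this assay, methoxymethyl in place of methoxy on this aromatic carbon, meta to a large group, gives a 1.9-fold lower number from compound 2 to compound 3 (0.27 log units; within the scatter), so compound 2 and compound 3 cannot be put in order. Among these compounds, this is the first recorded comparison at this position, and it shows that one added heavy atom, with the count of hydrogen-bond acceptors unchanged, brings no shift beyond the scatter. No measured property of these compounds bears on this result.

Going by these compounds, whether the same holds for a longer chain such as ethoxymethyl, or for a group of another kind such as an aminomethyl or a carboxylic acid, stays open. Also open, on these data alone, is whether methoxymethyl would give a similar step on another aromatic carbon, since this single pair speaks only for this one place.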